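The source may report more compounds than this note shows. Statements on the series, on what has been measured and on what is new or still open speak of the compounds shown alone.

Compound 1 `Cc1cncc(C(=O)n2c(-c3cn(-c4ccccc4)nc3-c3ccc(F)cc3)nc3ccccc32)c1` gives 119000 nM in an ADME assay on HEK-293T cells (Homo sapiens) for cytotoxicity, read by MTT assay, with a stated time of 24 h (on this read-out higher numbers stand for lower toxicity in this test and lower numbers for higher toxicity in this test), the lowest of the three numbers shown, though compound 3 `Cc1ccc(-c2nn(-c3ccccc3)cc2-c2nc3ccccc3n2C(=O)c2cncc(C)c2)cc1` with 155000 nM and compound 2 `O=C(c1ccc(Cl)cc1)n1c(-c2cn(-c3ccccc3)nc2-c2ccc(C(F)(F)F)cc2)nc2ccccc21` with 181000 nM both lie within the scatter of it. Going by the values given here, the only single-point step among the measured compounds, a 1.3-fold higher number from compound 1 to compound 3 (0.11 log units; within the scatter), concerns another exchange and was itself within the scatter. Compound 4 `O=C(c1cccnc1)n1c(-c2cn(-c3ccccc3)nc2-c2ccc(F)cc2)nc2ccccc21` differs from compound 1 by hydrogen in place of methyl on an aromatic carbon. Among the compounds with values here, no measured pair bears directly on this change, and all three numbers sit close together, so no move beyond the scatter is expected in this assay. Compound 4 is therefore expected to give 119000 nM, between 60000 nM and 240000 nM. The step from compound 1 is expected as no change at the digits printed from compound 1 to compound 4 (within the scatter).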

Compound 4, half-maximal cytotoxic concentration: 216000 nM
The estimate for compound 4 lay 1.8-fold (0.26 log units) below the measured number; measured number inside the range.
By their numbers in this assay, from the lowest: compounds 1, 3, 2 and 4 (each within the scatter of the next).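

Going from 5-methylpyridin-3-yl to pyridin-3-yl in this assay gives a 1.8-fold higher number from compound 1 to compound 4 (0.26 log units; within the scatter), the first reading of any exchange at this place on the ring. Here the methyl can give way to hydrogen with the number staying inside the scatter, so this carbon shows no dependence on that methyl in this test. Nothing measured explains this result or links it to any property of the methyl. Still open, as far as these compounds go, is whether an amine or a carboxylic acid in place of this methyl would move the number beyond the scatter. Also open, from the compounds shown here alone, is whether hydrogen in place of methyl reads the same on the core of compound 3.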